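Chalcone amide series: nitro for isobutyl on Vero cells

The compounds below may be only part of what the source reports. "The series", "measured", "known", "first", "only" and "open" are said of these compounds alone.

The series is followed in an ADME assay on Vero cells (Chlorocebus sabaeus) for cytotoxicity, read by MTT assay, with a stated time of 72 h; a lower number here means that less compound is tolerated, a higher number that more compound is tolerated. Compound 1 `CCCOc1ccc(C(=O)/C=C/c2ccc(C(=O)O)cc2)cc1` gives < 10 ug/mL, a limit of the assay and not a number. Compound 2 `COC(=O)c1cc(-c2cccc(NC(=O)c3ccc(/C=C/C(=O)c4ccc(CC(C)C)cc4)cc3)c2)on1` gives > 10 ug/mL, again only a limit of the assay. Compound 3 `CCOC(=O)c1cc(-c2cccc(NC(=O)c3cccc(C(F)(F)F)c3)c2)on1` carries no result, with "not determined" (no result reported) noted in its place. Compound 2 therefore stands at the upper of the two limits among the values shown: one entry sits at the limit of < 10 ug/mL in this assay, at which 1 of the 3 values shown sits, one at the limit of > 10 ug/mL in this assay, at which 1 of the 3 values shown sits, and one has no number at all, so no ordering among the three can be read.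

Compound 4 `COC(=O)c1cc(-c2cccc(NC(=O)c3ccc(/C=C/C(=O)c4ccc([N+](=O)[O-])cc4)cc3)c2)on1` differs from compound 2 at one place: nitro in place of isobutyl on an aromatic carbon. Within the data shown here, no step between two measured compounds exists for this exchange, and the values of compound 1 and compound 2 are limits on opposite sides, so they set no direction. The step from compound 2 to compound 4 is expected to be a step that the limit leaves unreadable from compound 2 to compound 4, that is, no change beyond the scatter, since nothing shown argues for one. For compound 4 the estimate is 15 ug/mL, with a range from 5 ug/mL to 60 ug/mL, and a result reported only as a limit is considered likely.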

Compound 4, half-maximal cytotoxic concentration: > 20 ug/mL
Compound 4: only a limit was reported; the forecaster's own chance of this, stated with the estimate: 60%; middle value at least 1.3-fold (0.12 log units) away from the limit.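

In this assay compound 4 gives > 20 ug/mL, a limit of the assay and not a number. Among these compounds, compound 2 gives > 10 ug/mL, also only a limit, and no step for nitro in place of isobutyl can be read between compound 2 and compound 4. The compounds shown leave open where either true value lies, and whether this exchange shifts the tolerated concentration at all.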